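Title: Cytotoxicity of a lignan-type lactone with a triazole ether

A few compounds are considered here, and "the series" means these few. Any claim that something is new, unique, unknown or untested is made for them only; others in the source may bear on it.

Measured so far:
compound 1, `COc1ccc(C[C@H]2COC(=O)[C@@H]2Cc2ccc(OCc3cn(Cc4ccccc4F)nn3)c(OC)c2)cc1OC`: >= 600000 nM
compound 2, `CCN(CC)C(=O)COc1ccc(C[C@H]2C(=O)OC[C@@H]2Cc2ccc(OC)c(OC)c2)cc1OC`: 188000 nM

Two compounds have been run in an ADME assay on HeLa cells (Homo sapiens) for cytotoxicity, read by MTT assay; on this read-out lower numbers stand for stronger inhibition and higher numbers for weaker inhibition. Compound 1 reaches only the limit of the assay there, >= 600000 nM, and gives no number. For the measured compounds named here, compound 2 is the only compound with a number on this read-out, at 188000 nM in this assay. Going by the values given here, its standing can therefore be set only against the one other value, which is not a number.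

Compound 3, `COc1ccc(C[C@H]2COC(=O)[C@@H]2Cc2ccc(OCc3cn(-c4cccc(Cl)c4)nn3)c(OC)c2)cc1OC`, has not been measured yet. It differs from compound 2 in one place: 1-(3-chlorophenyl)-1H-1,2,3-triazol-4-yl in place of diethylcarbamoyl on a saturated chain carbon bound to an oxygen on an aromatic ring.

Among the compounds with values here, no step between two measured compounds is available to lean on, so the expectation rests on the standing of the two values alone. Within the data shown here, the account expects the step from compound 2 to compound 3 in this assay to be toward weaker inhibition, a 2.4-fold higher number from compound 2 to compound 3 (0.38 log units; beyond the scatter), well beyond the usual scatter, because the one other compound carrying a large ether group sits at the limit (the limit of >= 600000 nM in this assay, at which 1 of the 2 values shown sits). Compound 3 is thus estimated at 450000 nM in this assay, within a range from 150000 nM to 1000000 nM, with a fair chance that only a limit is reported.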

Compound 3, half-maximal inhibitory concentration: 493000 nM
Compound 3: the middle estimate sits 1.1-fold (0.04 log units) below what was measured; the measured number falls inside the stated range.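

In this assay, for the compounds shown here, compound 3 gives the first number for a triazole ether at this place, on a saturated chain carbon bound to an oxygen on an aromatic ring, so the change from diethylcarbamoyl to 1-(3-chlorophenyl)-1H-1,2,3-triazol-4-yl now has a size: a 2.6-fold higher number from compound 2 to compound 3 (0.42 log units; beyond the scatter). This is a modest move toward weaker inhibition, and it lies beyond the scatter. The change on the aromatic nitrogen, 3-chlorophenyl in place of 2-fluorobenzyl, gives an at least 1.2-fold lower number from compound 1 to compound 3 (0.08 log units; that floor lies within the scatter), and with that floor inside the scatter it cannot be said to shift the read-out in either direction, as compound 1 is held at a limit and not a number: the limit of >= 600000 nM in this assay, at which 1 of the 3 values shown sits.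

The compounds shown leave open whether the step from compound 2 belongs to the triazole ring itself or to the aryl group it carries, which a methyl or a plain phenyl on the triazole nitrogen would begin to separate. They also leave open how a smaller ether at the same place, such as one ending in an amine or a carboxylic acid, would read in this assay.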